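This account rests on a few compounds, and the source may have more. Where it says the series, first, only, none or still open, it means among the compounds named here.

Measured so far:
- compound 1 `Cc1ccc(OCCCN(Cc2ccc(C(=O)NO)cc2)c2ncc(-c3ccc(C)cc3)s2)cc1`: 9330 nM
- compound 2 `CCCCN(Cc1ccc(C(=O)NO)cc1)c1ncc(-c2ccc(C)cc2)s1`: 6410 nM

In a functional assay on PC-3 cells (Homo sapiens) for antiproliferative activity, read by MTT assay, with a stated time of 48 h (on this read-out higher numbers stand for weaker inhibition of growth and lower numbers for stronger inhibition of growth), compound 1 gives 9330 nM, which lies within the scatter of compound 2 at 6410 nM. Compound 3 `Cc1ccc(-c2cnc(N(CCCOc3ccccc3)Cc3ccc(C(=O)NO)cc3)s2)cc1` differs from compound 1 by hydrogen in place of methyl on an aromatic carbon, reading 4-methylphenoxy to phenoxy. Going by the values given here, the only measured step bearing on this, a 1.5-fold lower number from compound 1 to compound 2 (0.16 log units; within the scatter), replaces the whole 4-methylphenoxy with methyl and stays within the scatter. No shift beyond the scatter is therefore expected in this assay from the smaller change. The expected step is a 1.2-fold lower number from compound 1 to compound 3 (0.07 log units; within the scatter). For compound 3 the estimated value is 8000 nM, with an expected range of 4000 nM to 16000 nM.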

Compound 3, concentration for 50% growth inhibition: 17500 nM
Compound 3: middle estimate off by 2.2-fold (0.34 log units), on the low side, outside the stated range (above it).
By their numbers in this assay, from the lowest: compounds 2, 1 and 3 (each within the scatter of the next, the first and the last beyond it).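

In this assay, hydrogen in place of methyl on the aromatic carbon gives a 1.9-fold higher number from compound 1 to compound 3 (0.27 log units; within the scatter) and so shows no clear effect of this methyl. Phenoxy in place of methyl on the chain gives a 2.7-fold higher number from compound 2 to compound 3 (0.44 log units; beyond the scatter) and is the first step in the series beyond the scatter, though a modest one, so the end of this chain can register where the step between compound 1 and compound 2 did not. No supporting data on hand account for this step. On these data alone, whether an amine or a carboxylic acid at this chain end would shift the number stays open. So does the effect of a longer chain.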